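The source may hold more compounds than are shown below. What is called first, only, known or untested is meant among the compounds shown, and "the series" means these compounds.

Within the data shown here, in an ADME assay on cells (Homo sapiens) for cytotoxicity, read by resazurin assay, with a stated time of 5 days (a lower number here means that less compound is tolerated, a higher number that more compound is tolerated), compound 2 `O=S(=O)(Cc1nc(-c2ccnc(Cl)c2)c2sccc2n1)c1cccc(Cl)c1` gives 63000 nM, the only actual number in the set. Compound 1 `O=S(=O)(Cc1nc(-c2ccncc2)c2sccc2n1)c1cccc(Cl)c1` reads > 50000 nM, which is a limit. Compound 3 `COc1ccc(-c2nc(CCS(=O)(=O)c3cccc(Cl)c3)nc3ccsc23)cn1` reads > 50000 nM, also a limit. Both therefore sit at the limit of > 50000 nM in this assay, at which 2 of the 3 values shown sit.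

Compound 4 `O=S(=O)(Cc1nc(-c2cccs2)c2sccc2n1)c1cccc(Cl)c1` carries thiophen-2-yl in place of 2-chloropyridin-4-yl on an aromatic carbon. Among the measured compounds shown here, the only measured step at this substituent is a step that the limit leaves unreadable from compound 1 to compound 2, so it offers no size to carry over. With compound 2 at 63000 nM, no change beyond the scatter is expected in this assay. The expected step is a 1.4-fold lower number from compound 2 to compound 4 (0.15 log units; within the scatter). For compound 4 the estimate is 45000 nM, with an expected range of 18000 nM to 80000 nM.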

Compound 4, half-maximal cytotoxic concentration: > 50000 nM
Compound 4 gave a limit, no number (the forecaster's own chance of this, stated with the estimate: 55%); middle value at least 1.1-fold (0.04 log units) away from the limit.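

Compound 4 reads as a limit, so no step from compound 1 or compound 2 to compound 4 can be read: the limit of > 50000 nM in this assay, at which 3 of the 4 values shown sit.

The compounds shown leave open whether compound 1, compound 2 and compound 4 truly differ in this assay.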